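Removing the chloro group from compound 3

The compounds below may be only part of what the source reports. "The series", "measured", "known", "first", "only" and "open" are said of these compounds alone.

Measured in a functional assay on HT-29 cells (Homo sapiens) for antiproliferative activity, read by sulforhodamine B assay, with a stated time of 72 h; a higher number here means a weaker inhibitor, a lower number a stronger inhibitor:
compound 1 (`S=C(N/N=C/c1ccc2ccccc2n1)Nc1cccc(Br)c1`) gives 58900 nM
compound 2 (`COc1cccc(NC(=S)N/N=C/c2ccc3ccccc3n2)c1`) gives 82400 nM
compound 3 (`S=C(N/N=C/c1ccc2ccccc2n1)Nc1cccc(Cl)c1`) gives 48100 nM

The values of compound 3 and of both other compounds lie within the scatter of one another. Hydrogen in place of chloro on an aromatic carbon leads to compound 4 (`S=C(N/N=C/c1ccc2ccccc2n1)Nc1ccccc1`), not yet measured. Three measured steps exchange the group on that carbon, and all stay within the scatter (a 1.4-fold higher number from compound 1 to compound 2 (0.15 log units; within the scatter); a 1.2-fold lower number from compound 1 to compound 3 (0.09 log units; within the scatter); a 1.7-fold lower number from compound 2 to compound 3 (0.23 log units; within the scatter)). None of them tests a bare hydrogen there, so the evidence is indirect. No change beyond the scatter is expected (a 1.2-fold higher number from compound 3 to compound 4 (0.10 log units; within the scatter)). Compound 4 is expected at 60000 nM (estimated range 30000 nM to 120000 nM).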

Compound 4, half-maximal inhibitory concentration: 17000 nM
For compound 4 the middle estimate is 3.5-fold (0.55 log units) above the measured one; measured number outside the range, below it.
By their numbers in this assay, from the lowest: compound 4; then compounds 3, 1 and 2 (each within the scatter of the next).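

In this assay the change from 3-chlorophenyl to phenyl gives a 2.8-fold lower number from compound 3 to compound 4 (0.45 log units; beyond the scatter) and goes beyond the scatter, which no exchange among the bromo, chloro and methoxy compounds did. The other two groups give the same direction when replaced by hydrogen, with a 3.5-fold lower number from compound 1 to compound 4 (0.54 log units; beyond the scatter) and a 4.8-fold lower number from compound 2 to compound 4 (0.69 log units; beyond the scatter), so among these four compounds hydrogen on that carbon gives the lowest number. Nothing available here accounts for this difference.

From the compounds shown here alone, whether an amine or a carboxylic acid on that carbon would stand with hydrogen or with the bromo, chloro and methoxy compounds remains open. Also open, going by these compounds, is whether the same step holds on another core.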